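This account rests on a few compounds, and the source may have more. Where it says the series, first, only, none or still open, it means among the compounds named here.

Compound 2 `N#Cc1ccccc1NC(=O)N1CCC(c2nc(-c3ccc4ccccc4n3)no2)CC1` gives the lowest number of the three in a functional assay on Shh Light II cells (Mus musculus) for inhibition, read by a luciferase reporter; on this read-out lower numbers stand for stronger inhibition and higher numbers for weaker inhibition: compound 2 gives 190 nM. Going by the values given here, compound 1 `C[C@@H]1C[C@H](c2nc(-c3ccc4ccccc4n3)no2)CCN1C(=O)Nc1ccccc1Cl` gives 2400 nM and compound 3 `C[C@H]1C[C@H](c2nc(-c3ccc4ccccc4n3)no2)CCN1C(=O)Nc1ccccc1Cl` gives 900 nM; the one single-point step among the measured compounds, a 2.7-fold lower number from compound 1 to compound 3 (0.43 log units; beyond the scatter), rests on the fact that compounds 1 and 3 differ only in the configuration as drawn and concerns the saturated ring, not the aryl urea end. Compound 4 `Cc1ccccc1NC(=O)N1CCC(c2nc(-c3ccc4ccccc4n3)no2)CC1` differs from compound 2 by methyl in place of cyano on an aromatic carbon. Among the compounds with values here, no measured step varies this position; compounds 1 and 3 differ from compound 2 in two places at once, so their values show only that those other patterns sit above compound 2. The step from compound 2 to compound 4 is therefore expected to be a 2.1-fold higher number from compound 2 to compound 4 (0.32 log units; beyond the scatter), a weakening of modest size with wide uncertainty. Compound 4 is estimated at 400 nM, in the range 120 nM to 1500 nM.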

Compound 4, half-maximal inhibitory concentration: 440 nM
Estimate against measurement, compound 4: 1.1-fold (0.04 log units) below, and the stated range covers the measured number.
By their numbers in this assay, from the lowest: compound 2; then compound 4; then compound 3; then compound 1.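

Methyl in place of cyano on this aromatic carbon gives a 2.3-fold higher number from compound 2 to compound 4 (0.36 log units; beyond the scatter) in this assay and is the first measured step at this position. The nitrile is therefore not required for inhibition, although cyano gives the lower number of this pair. Nothing available bears on what lies behind this step.

Open, going by these compounds, is how methoxy, trifluoromethyl or plain hydrogen would read on this carbon. Also open, on these data alone, is whether the same exchange gives a similar step on the methyl-bearing saturated ring of compound 1 or compound 3.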